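The source may report more compounds than this note shows. Statements on the series, on what has been measured and on what is new or still open speak of the compounds shown alone.

Measured so far:
compound 1, `CC(C)=CC[C@@H](OC(=O)C1CCCO1)C1=CC(=O)c2c(O)ccc(O)c2C1=O`, 17000 nM
compound 2, `CC[C@](C)(O)CC(=O)O[C@H](CC=C(C)C)C1=CC(=O)c2c(O)ccc(O)c2C1=O`, 30200 nM
compound 3, `CCCCC(CC(=O)O[C@H](CC=C(C)C)C1=CC(=O)c2c(O)ccc(O)c2C1=O)OC(C)=O`, 73500 nM

All three share the same core and differ only in the ester group attached to it. In a functional assay on HeLa cells (Homo sapiens) for cytotoxicity, read by MTT assay (on this read-out lower numbers stand for stronger inhibition and higher numbers for weaker inhibition), compound 3 gives the highest number of the three, and so the weakest inhibition: the step of a 2.4-fold higher number from compound 2 to compound 3 (0.39 log units; beyond the scatter) and the step of a 4.3-fold higher number from compound 1 to compound 3 (0.64 log units; beyond the scatter) both lie beyond the scatter. Compound 4, `CCCCCCC(C)(O)CC(=O)O[C@H](CC=C(C)C)C1=CC(=O)c2c(O)ccc(O)c2C1=O`, has not been measured. It differs from compound 3 in this way: 1-hydroxy-1-methylheptyl in place of 1-acetoxypentyl on a saturated chain carbon bound to a carbonyl carbon. The measured step that bears most directly on it is a 2.4-fold higher number from compound 2 to compound 3 (0.39 log units; beyond the scatter), in which 1-acetoxypentyl took the place of 1-hydroxy-1-methylpropyl and the number rose. Compound 4 reverses that kind of exchange, restoring a hydroxy-bearing group, though one with a longer chain for which no measured comparison exists. A step back toward compound 2 is therefore expected, a 2.1-fold lower number from compound 3 to compound 4 (0.32 log units; beyond the scatter), in the direction of stronger inhibition. Compound 4 is expected to give about 35000 nM, within a range from 15000 nM to 80000 nM.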

Compound 4, half-maximal inhibitory concentration: > 100000 nM
Compound 4: a limit, no number; the forecaster's own chance of this, stated with the estimate: 5%; middle value at least 2.8-fold (0.45 log units) away from the limit.
By their numbers in this assay, from the lowest: compounds 1 and 2 (each within the scatter of the next); then compound 3. At a limit, above all of these: compound 4.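

In this assay compound 4 gives no number, only a limit of the assay: the limit of > 100000 nM in this assay, at which 1 of the 4 values shown sits. Going by these compounds alone, a hydroxy-bearing group on this saturated chain carbon bound to a carbonyl carbon therefore does not by itself keep the number near that of compound 2: with 1-hydroxy-1-methylheptyl in place of 1-hydroxy-1-methylpropyl, the result is an at least 3.3-fold higher number from compound 2 to compound 4 (0.51 log units; beyond the scatter), so the length of the chain matters here, which the earlier compounds could not show. The exchange for oxolan-2-yl gives an at least 5.8-fold higher number from compound 1 to compound 4 (0.76 log units; beyond the scatter), while the exchange for 1-acetoxypentyl gives an at least 1.3-fold higher number from compound 3 to compound 4 (0.13 log units; that floor lies within the scatter), so that floor alone does not separate these two groups.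

Open, going by these compounds, is how the number changes for chains of intermediate length, such as 1-hydroxy-1-methylbutyl. Also open, on these data alone, is what an amine or a carboxylic acid would do on this chain.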